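A few compounds are considered here, and "the series" means these few. Any claim that something is new, unique, unknown or untested is made for them only; others in the source may bear on it.

Measured so far in an in vitro assay on BHK cells for inhibition of Glucagon receptor (Homo sapiens); a higher number here means a weaker inhibitor, a lower number a stronger inhibitor:
- compound 1, `CC(C)(C)[C@H]1CC[C@H](N(Cc2ccc(C(=O)NCCC(=O)O)cc2)C(=O)Nc2cc(C(F)(F)F)cc(C(F)(F)F)c2)CC1`: compound 1 gives 56 nM
- compound 2, `CC(C)(C)[C@H]1CC[C@H](N(Cc2ccc(C(=O)NCCC(=O)O)cc2)C(=O)Nc2ccc(C#N)cc2OC(F)(F)F)CC1`: compound 2 gives 215 nM
- compound 3, `COC1CCC(N(Cc2ccc(C(=O)NCCC(=O)O)cc2)C(=O)Nc2ccc(OC(F)(F)F)cc2)CC1`: compound 3 gives only a limit of the assay, > 10000 nM

Compound 3 thus stands apart from the two numbers in the series: its result is not a number but (the limit of > 10000 nM in this assay, at which 1 of the 3 values shown sits). Among the compounds with values here, compound 1 and compound 2 differ from compound 3 in more than one place, so no single step connects their values to the limit, and nothing can be read from them about the size of any one change.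

Compound 4, `CCCC1CCC(N(Cc2ccc(C(=O)NCCC(=O)O)cc2)C(=O)Nc2ccc(OC(F)(F)F)cc2)CC1`, is the next compound in the series. It differs from compound 3 in one place: propyl in place of methoxy on a saturated ring carbon. Within the data shown here, no step between measured compounds in this assay touches this position, so the size of the step from compound 3 to compound 4 is not known from the data.

The expectation is a gain in this assay, the estimated step being an at least 2.5-fold lower number from compound 3 to compound 4 (0.39 log units; beyond the scatter), with a real chance that compound 4 also reaches only the limit. Compound 4 is therefore estimated at 4000 nM, in the range from 1000 nM to 10000 nM.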

Compound 4, half-maximal inhibitory concentration: 122 nM
For compound 4 the middle estimate is 33-fold (1.52 log units) above the measured one, and the stated range ends above it.
By their numbers in this assay, from the lowest: compound 1; then compounds 4 and 2 (each within the scatter of the next). At a limit, above all of these: compound 3.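

In this assay, within the data shown here, propyl in place of methoxy on a saturated ring carbon, three ring bonds from the ring atom that bears a large group, gives an at least 81-fold lower number from compound 3 to compound 4 (1.91 log units; beyond the scatter), the first step that can be read at a single position. This step is a minimum and not a measured size, because compound 3 stands at a limit of the assay: the limit of > 10000 nM in this assay, at which 1 of the 4 values shown sits. The change from 4-methoxycyclohexyl to 4-propylcyclohexyl is therefore enough on its own, with the rest of the molecule unchanged, to take this pair from a limit to a numerical value, which shows that this ring position strongly affects the read-out.

The step combines the loss of the oxygen with the change of chain, and the compounds shown do not separate the two; an ethyl group, a butyl chain or a hydroxyl group at this ring carbon would bear on that question. As far as these compounds go, the steps linking compound 1 and compound 2 to the others cannot be read, so it stays open whether this change would have a similar effect alongside the other groups in those compounds.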